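This account rests on a few compounds, and the source may have more. Where it says the series, first, only, none or still open, it means among the compounds named here.

Going by the values given here, compound 3 `O=[N+]([O-])c1ccc(O)c(CSc2ncnc3c2ncn3[C@@H]2O[C@H](CO)[C@@H](O)[C@H]2O)c1` gives the lowest number so far in an assay on isolated protein for binding affinity to Equilibrative nucleoside transporter 1 (Homo sapiens); on this read-out higher numbers stand for weaker inhibition and lower numbers for stronger inhibition: it reaches 33.1 nM. Compound 1 `OC[C@H]1O[C@@H](n2cnc3c(OCc4ccccc4)ncnc32)[C@H](O)[C@@H]1O` sits well behind it with 2090 nM, and compound 2 `OC[C@H]1O[C@@H](n2cnc3c(SC4CCCCC4)ncnc32)[C@H](O)[C@@H]1O` further still with 6310 nM. Among the compounds with values here, the one step measured between neighbouring structures, a 3.0-fold higher number from compound 1 to compound 2 (0.48 log units; beyond the scatter), shows that swapping the benzyloxy group for a cyclohexylsulfanyl group weakened binding. Compound 4 `Cc1ccc(CSc2ncnc3c2ncn3[C@@H]2O[C@H](CO)[C@@H](O)[C@H]2O)cc1` is compound 3 with one change: 4-methylphenyl in place of 2-hydroxy-5-nitrophenyl on a saturated chain carbon bound to a sulfur. Within the data shown here, no measured pair matches this change exactly. What the numbers show is that compound 1, carrying a plain benzyl group on oxygen, is far weaker than compound 3, and compound 4 keeps the sulfur link of compound 3 but loses the hydroxy and nitro groups, so its benzyl portion comes closer to that of compound 1. The step of a 15-fold higher number from compound 3 to compound 4 (1.18 log units; beyond the scatter) is therefore expected to be a clear weakening, landing between the numbers of compound 3 and compound 1. Compound 4 is estimated at 500 nM, within a range from 100 nM to 3000 nM.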

Compound 4, half-maximal inhibitory concentration: 457 nM
The estimate for compound 4 lay 1.1-fold (0.04 log units) above the measured number; the range from low to high includes it.
By their numbers in this assay, from the lowest: compound 3; then compound 4; then compound 1; then compound 2.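

With the sulfur link held fixed, the groups on the phenyl ring matter greatly in this assay: exchanging 2-hydroxy-5-nitrophenyl for 4-methylphenyl gives a 14-fold higher number from compound 3 to compound 4 (1.14 log units; beyond the scatter) and so costs much of the binding. The ring itself also counts for something, since 4-methylbenzyl in place of cyclohexyl on a sulfur gives a 14-fold lower number from compound 2 to compound 4 (1.14 log units; beyond the scatter) even without the hydroxy and nitro groups. As far as these compounds go, the step of a 4.6-fold lower number from compound 1 to compound 4 (0.66 log units; beyond the scatter) is smaller and comes with (4-methylbenzyl)sulfanyl in place of benzyloxy, which alters the oxygen link and adds the methyl group in one move, so the share of each stays unknown.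

The compounds shown leave open whether the hydroxy group, the nitro group or the two together account for the large step. They also leave open whether an amine or a carboxylic acid on the ring would serve as well. No evidence on hand explains the size of these steps.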